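A Fluorine Swap on a Furan-Bearing Enone

A few compounds are considered here, and "the series" means these few. Any claim that something is new, unique, unknown or untested is made for them only; others in the source may bear on it.

Of the compounds shown here, three have been measured so far.

Compound 1 `Cc1nc(NC(=O)c2ccccc2)sc1C(=O)/C=C/c1ccccc1` gives 73.5% in an assay for inhibition of Polyunsaturated fatty acid 5-lipoxygenase (Homo sapiens), read by spectrophotometry, tested at 10 uM, in the presence of a further agent that is not named here; on this read-out lower numbers stand for less inhibition and higher numbers for more inhibition at the one concentration tested (going by the name of the read-out).
Compound 2 `Cc1nc(NC(=O)c2ccccc2)sc1C(=O)/C=C/c1ccc(F)cc1` gives 98% in this assay.
Compound 3 `Cc1nc(NC(=O)c2ccccc2)sc1C(=O)/C=C/c1ccco1` gives 57.2% in this assay.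

All three share the same core, an amide-bearing ring joined through a carbonyl to a double-bonded chain that ends in an aromatic group. Compound 1 and compound 3 differ in that group: furan-2-yl in place of phenyl on a double-bonded chain carbon bound to a double-bonded chain carbon. That change made a number 16.3 percentage points lower from compound 1 to compound 3 (beyond the scatter). Compound 1 and compound 2 differ by a single atom: fluoro in place of hydrogen on an aromatic carbon. That change made a number 24.5 percentage points higher from compound 1 to compound 2 (beyond the scatter). Compound 3 stands lowest of the three, and against compound 2 the gap is a number 40.8 percentage points lower from compound 2 to compound 3 (beyond the scatter).

Compound 4 `Cc1nc(NC(=O)c2ccc(F)cc2)sc1C(=O)/C=C/c1ccco1` has not yet been measured. It carries the furan-2-yl group of compound 3, and differs from compound 3 as follows: fluoro in place of hydrogen on an aromatic carbon. For the measured compounds named here, this is the same change as the one between compound 1 and compound 2, made on the same kind of place, so the earlier step is the only guide to what it may do here.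

The step of a number 18.8 percentage points higher from compound 3 to compound 4 (beyond the scatter) is expected to be of a similar size to the earlier one, because a number 24.5 percentage points higher from compound 1 to compound 2 (beyond the scatter). Whether the furan-bearing core answers the added fluorine in the same way is not known from these three compounds, so the range is kept wide. Compound 4 is therefore estimated at 76% in this assay, expected to fall between 56% and 95%.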

Compound 4, a percentage reported as inhibition, at one concentration (the size of the read-out at that concentration, not a potency): 65.3%
Compound 4: the middle estimate sits 10.7 percentage points above what was measured; the measured number falls inside the stated range.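

In this assay, putting fluoro in place of hydrogen made a number 8.1 percentage points higher from compound 3 to compound 4 (within the scatter), so on this core the change cannot be told apart from the ordinary spread of repeat measurements. The change therefore did not carry over at the size seen before, and the gap between the two steps is real rather than noise: the same change on two cores in this assay, a number 24.5 percentage points higher (beyond the scatter) from compound 1 to compound 2 and a number 8.1 percentage points higher (within the scatter) from compound 3 to compound 4, 16.4 percentage points apart, beyond the scatter of two such steps

This does not show that fluoro has no effect on the furan-bearing compounds, and one pair on each core cannot explain the gap, since the two steps differ in more than the core: in compound 2 the fluoro sits on the phenyl at the end of the double-bonded chain, while in compound 4 it sits on the phenyl of the amide.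

The compounds shown leave open whether a fluoro on the amide phenyl of a compound ending in phenyl would behave as it does in compound 4, a pair that would separate the effect of the ring carrying the fluoro from that of the furan-2-yl group. They also leave open how other groups in the same place, such as chloro, methoxy or an amine, would behave on either core.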